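The compounds below may be only part of what the source reports. "The series", "measured", "known", "first", "only" and "open" are said of these compounds alone.

Compound 1 `CCOC(=O)c1cnc(NC2CC2)n2nc(-c3ccco3)nc12` and compound 2 `CCOC(=O)c1cnc(NC2CCCC2)n2nc(-c3ccco3)nc12` share one core and differ only in the ring attached to the nitrogen on an aromatic ring. In a functional assay on CHO cells for antagonist activity at adenosine receptor A2b (Homo sapiens) (on this read-out lower numbers stand for stronger inhibition and higher numbers for weaker inhibition), compound 1 gives 2260 nM. In this assay, within the data shown here, compound 2 gives 4620 nM, the higher of the two numbers, with compound 1 as its only neighbour. Among the measured compounds shown here, the single measured step, a 2.0-fold higher number from compound 1 to compound 2 (0.31 log units; beyond the scatter), runs toward weaker inhibition when the smaller ring is replaced by the larger one. Compound 3 `CCOC(=O)c1cnc(NC2CCCCC2)n2nc(-c3ccco3)nc12` carries the next larger ring: cyclohexyl in place of cyclopentyl on a nitrogen on an aromatic ring. For the measured compounds named here, only that one modest step bears on this change, so a further movement of similar size toward a higher number, or none beyond the scatter, is expected. The step is estimated as a 1.4-fold higher number from compound 2 to compound 3 (0.15 log units; within the scatter). For compound 3 in this assay the expected value is 6500 nM, with a likely range from 2500 nM to 17000 nM.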

Compound 3, inhibition constant: > 10000 nM
Compound 3 ended at the assay's limit; the forecaster's own chance of this, stated with the estimate: 5%; at least 1.5-fold (0.18 log units) between middle value and limit.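

In this assay compound 3 gives > 10000 nM, which is a limit of the assay and not a number. Cyclohexyl in place of cyclopentyl on a nitrogen on an aromatic ring gives an at least 2.1-fold higher number from compound 2 to compound 3 (0.33 log units; beyond the scatter), and cyclohexyl in place of cyclopropyl gives an at least 4.4-fold higher number from compound 1 to compound 3 (0.64 log units; beyond the scatter), so a second step beyond the scatter now runs the same way as the first, and none of the three compounds goes against this order of ring size. Both new steps are bounds only, and the series has reached the end of what the read-out can show: the limit of > 10000 nM in this assay, at which 1 of the 3 values shown sits.

From the compounds shown here alone, how far compound 3 lies past that limit stays open, and with it the true size of both new steps. Also open, going by these compounds, is whether an open chain such as isopropyl, or a tetrahydropyranyl ring, would fit the same order of ring size at this nitrogen.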